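From benzyloxy to sulfooxy: working notes on compound 4

The compounds below may be only part of what the source reports. "The series", "measured", "known", "first", "only" and "open" are said of these compounds alone.

In an ADME assay on Vero cells (Chlorocebus sabaeus) for cytotoxicity, read by MTT assay, with a stated time of 72 h (a lower number here means that less compound is tolerated, a higher number that more compound is tolerated), compound 1 (`COc1ccc(/C=C/c2cc(SC)nc(N)n2)cc1OC`) reads 125000 nM as the lower of two numbers. Compound 2 (`CSc1cc(/C=C/c2ccc(OCc3ccccc3)cc2)nc(N)n1`) reads 376000 nM and so holds the higher number, and its distance from compound 1 lies beyond the usual scatter. For compound 3 (`COc1cc(/C=C/c2cc(SC)nc(N)n2)ccc1O`) the entry is "not determined" (no result reported) with no result reported, so it offers no guidance.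

Compound 4 (`CSc1cc(/C=C/c2ccc(OS(=O)(=O)O)cc2)nc(N)n1`) has not yet been measured. It departs from compound 2 by one change, sulfo in place of benzyl on an oxygen on an aromatic ring and nothing else.

Going by the values given here, no pair of measured compounds differs in one place, so the series does not size this change directly. With compound 1 at 125000 nM as the lower anchor and compound 2 at 376000 nM as the upper one, no move beyond the scatter is expected in this assay for this change, though a slight drift to a lower number is possible. The expected change is a 1.3-fold lower number from compound 2 to compound 4 (0.10 log units; within the scatter) on this estimate, and its uncertainty is wide. For compound 4 the estimated value is 300000 nM with an expected range from 100000 nM to 800000 nM as the working figure.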

Compound 4, half-maximal cytotoxic concentration: 301000 nM
Estimate against measurement, compound 4: 1.0-fold (0.00 log units) below; the measured number falls inside the stated range.
By their numbers in this assay, from the lowest: compound 1; then compounds 4 and 2 (each within the scatter of the next).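

The first step the series can size in this assay is a 1.2-fold lower number from compound 2 to compound 4 (0.10 log units; within the scatter), with sulfo in place of benzyl on an oxygen on an aromatic ring. The earlier compounds shown here gave no such step, and this one shows that at this place a benzyl group, with its six-membered aromatic ring of carbon only, can give way to a sulfo group with no ring, and the read-out stays within the scatter. Nothing available explains why these two quite different groups read alike, so the result stands as an observation without a cause.

Going by these compounds alone, still open is whether other groups on the same oxygen would also stay within the scatter, for instance a carboxymethyl group, an aminoethyl chain or a longer alkyl chain, since benzyl and sulfo are the only two groups compared at this place on an otherwise unchanged core. Also open, on these data alone, is whether the same exchange would read alike on the core of compound 1, where the aromatic ring carries different groups, as a single step cannot show how far this observation extends.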